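A one-group swap on a chain, not yet measured

The compounds below may be only part of what the source reports. "The series", "measured", "known", "first", "only" and "open" are said of these compounds alone.

Measured in a functional assay on HCT-116 cells (Homo sapiens) for inhibition, read by colorimetric assay, with a stated time of 3 days (on this read-out lower numbers stand for stronger inhibition and higher numbers for weaker inhibition), as follows:
- Compound 1 `C/C(=N\O)C(=O)NCCCCCC(=O)Nc1ccccc1` gives > 100000 nM as a limit
- Compound 2 `O=C(CCCCCCNC(=O)C(O)(O)C(F)(F)F)Nc1nc2ccccc2o1` gives 3450 nM as its value
- Compound 3 `O=C(CCCCCCNC(=O)C(O)(O)C(F)(F)F)Nc1nc(-c2ccccc2)c(-c2ccccc2)s1` gives 29900 nM as its value

Compound 1 offers no number and stands at the limit of > 100000 nM in this assay, at which 1 of the 3 values shown sits, in the data. That reading is a limit of the assay. Compound 4 `CC(=O)C(=O)NCCCCCCC(=O)Nc1ccccc1` has not yet been measured, and its change from compound 1 is this: a group of 7 heavy atoms (4 carbon, 1 nitrogen, 2 oxygen; no ring) in place of a group of 7 heavy atoms (3 carbon, 2 nitrogen, 2 oxygen; no ring), on a saturated chain carbon, five bonds along the chain from a carbonyl carbon. Among the measured compounds shown here, no measured step between compounds informs this change in this assay. A modest move toward stronger inhibition is expected, and the estimated step of an at least 1.6-fold lower number from compound 1 to compound 4 (0.22 log units; that floor lies within the scatter) reflects that. Compound 4 is estimated at 60000 nM with an expected range from 20000 nM to 100000 nM around that figure.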

Compound 4, half-maximal inhibitory concentration: > 100000 nM
Compound 4: no number, only a limit; the forecaster's own chance of this, stated with the estimate: 50%; middle value at least 1.6-fold (0.22 log units) from the limit.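

Among the compounds shown here, compound 1 and compound 4 both give only a limit of the assay, so no step between them can be read: the limit of > 100000 nM in this assay, at which 2 of the 4 values shown sit. The compounds shown leave open how far this swap on the chain shifts inhibition.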